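The source may report more compounds than this note shows. Statements on the series, on what has been measured and on what is new or still open speak of the compounds shown alone.

Three compounds share one core and were tested in an ADME assay on CCRF-CEM cells (Homo sapiens) for cytotoxicity, read by cell counting, with a stated time of 3 days; a lower number here means a stronger inhibitor, a higher number a weaker inhibitor. Compound 1, `O=c1[nH]c(=O)n([C@H]2C[C@H](O)[C@@H](CO)O2)cc1-c1cn(-c2ccccc2)nn1`, gives 75000 nM. Compound 2, `CCCCc1ccc(-n2cc(-c3cn([C@H]4C[C@H](O)[C@@H](CO)O4)c(=O)[nH]c3=O)nn2)cc1`, gives 60000 nM. Compound 3, `CSc1ccc(-n2cc(-c3cn([C@H]4C[C@H](O)[C@@H](CO)O4)c(=O)[nH]c3=O)nn2)cc1`, gives 50000 nM. On these numbers compound 3 has the lowest value of the three, yet it sits within the scatter of both neighbours: the step of a 1.5-fold lower number from compound 1 to compound 3 (0.18 log units; within the scatter) and the step of a 1.2-fold lower number from compound 2 to compound 3 (0.08 log units; within the scatter) are both too small to count as real differences.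

Compound 4, `O=c1[nH]c(=O)n([C@H]2C[C@H](O)[C@@H](CO)O2)cc1-c1cn(-c2ccc(Oc3ccccc3)cc2)nn1`, is the next compound to be measured. It differs from compound 3 by phenoxy in place of methylsulfanyl on an aromatic carbon. Among the compounds with values here, the steps that bear on this position are a 1.3-fold lower number from compound 1 to compound 2 (0.10 log units; within the scatter), a 1.5-fold lower number from compound 1 to compound 3 (0.18 log units; within the scatter) and a 1.2-fold lower number from compound 2 to compound 3 (0.08 log units; within the scatter), and each of them stayed within the scatter, so three different groups at this place have left this assay essentially unchanged. The expectation is therefore no step beyond the scatter, with the estimated change no change at the digits printed from compound 3 to compound 4 (within the scatter). Compound 4 is expected to give about 50000 nM, between 20000 nM and 120000 nM.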

Compound 4, half-maximal inhibitory concentration: 800 nM
Compound 4: middle estimate off by 63-fold (1.80 log units), on the high side, and the stated range ends above it.
By their numbers in this assay, from the lowest: compound 4; then compounds 3, 2 and 1 (each within the scatter of the next).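

In this assay, this position turns out not to be indifferent: phenoxy gives a 63-fold lower number from compound 3 to compound 4 (1.80 log units; beyond the scatter), and the picture is the same against the other two, with a 75-fold lower number from compound 2 to compound 4 (1.88 log units; beyond the scatter) and a 94-fold lower number from compound 1 to compound 4 (1.97 log units; beyond the scatter). The large step therefore holds whether phenoxy replaces methylsulfanyl, butyl or hydrogen, although those three groups stayed within the scatter of one another. Of the groups compared, only phenoxy brings a six-membered aromatic ring of carbon only, but nothing given here explains why the number falls so far.

Going by these compounds, it remains open whether the outer ring alone is enough or its oxygen link also matters, a question that a phenyl or benzyloxy group at this place would help to answer. Also open, on these data alone, is how a chlorine or a carboxylic acid on the outer ring would change the value.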